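Methoxy added to the fused ring of compound 1

The compounds below may be only part of what the source reports. "The series", "measured", "known", "first", "only" and "open" are said of these compounds alone.

Compound 1 `COc1ccc(-c2[nH]c3ccccc3c2/C=C(\C#N)S(=O)(=O)c2ccccc2)cc1` gives the lowest number of the three measured in a functional assay on NCI-H322M cells (Homo sapiens) for inhibition, read by sulforhodamine B assay, with a stated time of 48 h (on this read-out lower numbers stand for stronger inhibition of growth and higher numbers for weaker inhibition of growth), at 1500 nM. Compound 2 `COc1ccc2[nH]c(-c3ccccc3)c(C=C(C#N)C#N)c2c1` reaches 7400 nM in this assay, and compound 3 `CCOC(=O)C(=Cc1c(-c2ccccc2)[nH]c2ccccc12)C(=O)OCC` reaches 12700 nM; both gaps to compound 1 lie beyond the scatter, with compound 3 the furthest away. Among the compounds with values here, compound 2 and compound 3 differ from compound 1 in more than one place, so their values show only where compound 1 stands and carry no single-point step. Compound 4 `COc1ccc(-c2[nH]c3ccc(OC)cc3c2/C=C(\C#N)S(=O)(=O)c2ccccc2)cc1` arises from compound 1 through (methoxy in place of hydrogen on an aromatic carbon). Within the data shown here, no step between measured compounds bears on this change, so nothing beyond the scatter is expected in either direction: the step of no change at the digits printed from compound 1 to compound 4 (within the scatter) is estimated as small. Compound 4 is expected to give 1500 nM in this assay, within 600 nM to 4000 nM.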

Compound 4, concentration for 50% growth inhibition: 4300 nM
For compound 4 the middle estimate is 2.9-fold (0.46 log units) below the measured one, outside the stated range (above it).
By their numbers in this assay, from the lowest: compound 1; then compounds 4, 2 and 3 (each within the scatter of the next, the first and the last beyond it).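

In this assay, methoxy in place of hydrogen on this aromatic carbon of the fused system gives a 2.9-fold higher number from compound 1 to compound 4 (0.46 log units; beyond the scatter) and so weaker inhibition of growth. Within the data shown here, this is the first single-place step, and it shows that this position is not indifferent to substitution. Nothing available accounts for the step.

As far as these compounds go, whether the rise belongs to methoxy in particular or to any group at this carbon stays open. A hydroxyl, a fluorine or an amine at the same place would separate these readings.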